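This account rests on a few compounds, and the source may have more. Where it says the series, first, only, none or still open, it means among the compounds named here.

Compound 1 `C/C(=C\CC/C(C)=C/CC[C@@H]1[C@@]2(C)CCC(=O)C(C)(C)[C@H]2CC[C@@]1(C)O)CC/C=C(\C)C(=O)OCc1cn(-c2ccc(C(F)(F)F)cc2)nn1` is one of several esters built on a shared core, each carrying a different group on an aromatic nitrogen of a five-membered aromatic ring with 3 nitrogen. In a functional assay on A549 cells (Homo sapiens) for antiproliferative activity, read by MTT assay, with a stated time of 48 h (on this read-out lower numbers stand for stronger inhibition and higher numbers for weaker inhibition), compound 1 gives only a limit of the assay, > 150000 nM, so its place among the numbers shown is not fixed; it sits at the limit of > 150000 nM in this assay, at which 2 of the 3 values shown sit. Compound 2 `C/C(=C\CC/C(C)=C/CC[C@@H]1[C@@]2(C)CCC(=O)C(C)(C)[C@H]2CC[C@@]1(C)O)CC/C=C(\C)C(=O)OCc1cn(-c2ccccc2C(F)(F)F)nn1` likewise gives only a limit in this assay, > 150000 nM. Among the measured compounds shown here, compound 3 `C/C(=C\CC/C(C)=C/CC[C@@H]1[C@@]2(C)CCC(=O)C(C)(C)[C@H]2CC[C@@]1(C)O)CC/C=C(\C)C(=O)OCc1cn(C[C@@H]2O[C@H](n3ccc(=O)[nH]c3=O)C[C@H]2O)nn1`, which carries a sugar-like group on that nitrogen, gives 28100 nM in this assay, the one true number of the three. With both ends being limits, the step that the two limits leave unreadable from compound 1 to compound 2 cannot be sized.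

Compound 4 `C/C(=C\CC/C(C)=C/CC[C@@H]1[C@@]2(C)CCC(=O)C(C)(C)[C@H]2CC[C@@]1(C)O)CC/C=C(\C)C(=O)OCc1cn(-c2cccc(C)c2)nn1` differs from compound 1 by 3-methylphenyl in place of 4-(trifluoromethyl)phenyl on an aromatic nitrogen. For the measured compounds named here, the only measured step at this position is the unreadable one, so no sized step bears on this change, and the single number for compound 3 belongs to a quite different group. I therefore expect compound 4 to remain near the limit, with no step beyond the scatter, a number no higher from compound 1 to compound 4 (the limit leaves the size open). My estimate for compound 4 in this assay is 150000 nM, within 50000 nM to 450000 nM.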

Compound 4, half-maximal inhibitory concentration: > 150000 nM
Compound 4 ended at the assay's limit; the forecaster's own chance of this, stated with the estimate: 70%; the middle value lies on the limit itself.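

Compound 4 gives > 150000 nM in this assay, which is a limit of the assay and not a number. Its steps from compound 1 and from compound 2 cannot be read, as all three compounds stop at the same limit: the limit of > 150000 nM in this assay, at which 3 of the 4 values shown sit.

Still open, as far as these compounds go, is whether the 3-methylphenyl, 2-(trifluoromethyl)phenyl and 4-(trifluoromethyl)phenyl groups differ at all in this assay.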